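The source may report more compounds than this note shows. Statements on the series, on what has been measured and on what is new or still open speak of the compounds shown alone.

Compound 2 `N#Cc1cccc(-c2ccc(Cl)c(C(=O)NCC3(O)CCCCCC3)c2)n1` is measured in an in vitro ADME assay on microsomes from liver (Homo sapiens) for metabolic stability (on this read-out higher numbers stand for fast clearance and lower numbers for slow clearance), where it gives 47 mL/min/kg. Compound 1 `O=C(NCC1(O)CCCCCC1F)c1cc(-c2ncc(F)cn2)ccc1Cl` gives 15 mL/min/kg in this assay, so compound 2 stands as the higher of these two numbers, a gap beyond the scatter. Compound 3 `O=C(NCC1(O)CCCC(F)(F)CC1)c1cc(-c2ncc(F)cn2)ccc1Cl` sits at the limit of this assay, < 8 mL/min/kg, a limit rather than a number. Compound 4 `N#Cc1ccc(-c2ccc(Cl)c(C(=O)NCC3(O)CCCCCC3)c2)nc1` has not yet been measured; it differs from compound 2 in one place: 5-cyanopyridin-2-yl in place of 6-cyanopyridin-2-yl on an aromatic carbon. Going by the values given here, no measured pair shows the effect of such a swap, so no direction can be read from the data. The step from compound 2 to compound 4 is expected to be a 1.2-fold lower number from compound 2 to compound 4 (0.07 log units; within the scatter), not beyond the scatter. Compound 4 is therefore estimated at 40 mL/min/kg, between 20 mL/min/kg and 80 mL/min/kg.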

Compound 4, clearance: 37 mL/min/kg
Beside the measured number, compound 4's estimate is 1.1-fold (0.03 log units) above it; measured number inside the range.
By their numbers in this assay, from the lowest: compound 1; then compounds 4 and 2 (each within the scatter of the next). At a limit, below all of these: compound 3.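

Putting 5-cyanopyridin-2-yl in place of 6-cyanopyridin-2-yl gives, in this assay, a 1.3-fold lower number from compound 2 to compound 4 (0.10 log units; within the scatter). Going by these compounds alone, this is the first pair that isolates a single change at this position, on the aromatic carbon para to a chloro group, and shifting the nitrile within the pyridine ring does not separate the two compounds on this read-out. Nothing measured here offers an explanation for this result.

Going by these compounds, whether an amine or a carboxylic acid in place of the nitrile would change the clearance stays open. Compound 1 and compound 3 differ from these two in more than one place, so they cannot settle what this position contributes.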